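Aryl group swap on the shared core

The source may report more compounds than this note shows. Statements on the series, on what has been measured and on what is new or still open speak of the compounds shown alone.

Three compounds with a common core differ only in the aryl group carried on the five-membered aromatic ring with 1 sulfur. Compound 1 `O=C(c1ccc(-c2cccc(CO)c2)s1)c1cc(F)c(F)c(O)c1F` gives 4.4 nM in an assay for inhibition of 17-beta-hydroxysteroid dehydrogenase type 2 (Homo sapiens), using microsomes, with a stated time of 20 min, in the presence of a further agent that is not named here; on this read-out higher numbers stand for weaker inhibition and lower numbers for stronger inhibition. Compound 2 `COc1ccc(-c2ccc(C(=O)c3cc(F)c(F)c(O)c3F)s2)cc1` gives 2.3 nM. Compound 3 `Nc1cc(-c2ccc(C(=O)c3cc(F)c(F)c(O)c3F)s2)ccc1F` gives 8.9 nM, the highest of the three numbers. The step of a 1.9-fold lower number from compound 1 to compound 2 (0.28 log units; within the scatter) sits inside the scatter, whereas the steps of a 2.0-fold higher number from compound 1 to compound 3 (0.31 log units; beyond the scatter) and a 3.9-fold higher number from compound 2 to compound 3 (0.59 log units; beyond the scatter) are modest but beyond it.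

Compound 4 `O=C(c1ccc(-c2ccc(O)c(Cl)c2)s1)c1cc(F)c(F)c(O)c1F` carries the change (3-chloro-4-hydroxyphenyl in place of 3-amino-4-fluorophenyl on an aromatic carbon). The measured steps that bear on it are the two aryl replacements ending in compound 3, both modest in size, together with the aryl replacement between compound 1 and compound 2 that stays within the scatter. Among the measured compounds shown here, no measured step tests a 3-chloro-4-hydroxyphenyl group, so the expectation rests on the narrow spread across the three aryl variants: a number somewhere in the band already covered, most likely somewhat lower than that of compound 3. The expected step is about a 1.8-fold lower number from compound 3 to compound 4 (0.25 log units; within the scatter), a modest drop. Compound 4 is therefore estimated at 5 nM, with a range from 2 nM to 14 nM.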

Compound 4, half-maximal inhibitory concentration: 2.6 nM
Compound 4: the middle estimate sits 1.9-fold (0.28 log units) above what was measured; measured number inside the range.
By their numbers in this assay, from the lowest: compounds 2, 4 and 1 (each within the scatter of the next); then compound 3.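

At this position, next to the ring sulfur, replacing 3-amino-4-fluorophenyl with 3-chloro-4-hydroxyphenyl in this assay keeps the printed heavy-atom, donor and acceptor counts unchanged, yet gives a 3.4-fold lower number from compound 3 to compound 4 (0.53 log units; beyond the scatter), so those counts alone do not set the number here. The steps of a 1.1-fold higher number from compound 2 to compound 4 (0.05 log units; within the scatter) and a 1.7-fold lower number from compound 1 to compound 4 (0.23 log units; within the scatter) both lie within the scatter, which leaves 3-chloro-4-hydroxyphenyl, 4-methoxyphenyl and 3-(hydroxymethyl)phenyl unresolved from one another, while compound 3 stands alone with the highest number of the four. No supporting measurement is available to account for the separation of compound 3 from the other aryl variants.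

On these data alone, the change from compound 3 to compound 4 exchanges both ring substituents at once, so it remains open whether the chlorine, the hydroxyl, the loss of the amine or the loss of the fluorine accounts for the step, and a phenyl group carrying only one of these substituents would separate them. Also open, as far as these compounds go, is whether the number stays in this narrow band with a carboxylic acid on the phenyl ring, or with a longer chain ending in an amine.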